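From Propanoyl to Pyridin-3-yl on a Nitrogen

This account rests on a few compounds, and the source may have more. Where it says the series, first, only, none or still open, it means among the compounds named here.

For the measured compounds named here, only two compounds have been tested so far in a functional assay on the whole organism with Mus musculus as the target (a higher number here means that more compound is needed for the effect, a lower number that less compound is needed), and they differ in more than one place, so no single structural change can be read from them. In this test, compound 1 (`Cc1c(C)c2c(c(C)c1N)CC(C)(COCc1ccccc1)O2`) gives 18.6 mg/kg.

Compound 2 (`CCC(=O)Nc1c(C)c(C)c2c(c1C)CC(C)(C)O2`) gives > 100 mg/kg, which is a limit of the assay and not a number. Its true position is therefore unknown.

Compound 3 (`Cc1c(C)c2c(c(C)c1Nc1cccnc1)CC(C)(C)O2`) has pyridin-3-yl in place of propanoyl on a nitrogen on an aromatic ring. Going by the values given here, no measured pair shows what this swap does in this assay, so any forecast is loose. The one firm guide is compound 1 at 18.6 mg/kg, which shows that a measurable dose is possible among these few compounds.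

The expected change is a fall in the required dose, beyond the usual scatter, an at least 2.8-fold lower number from compound 2 to compound 3 (0.45 log units; beyond the scatter). The estimated value for compound 3 is 35 mg/kg, with an expected range of 10 mg/kg to 100 mg/kg.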

Compound 3, dose for 50% inhibition: > 50 mg/kg
Compound 3: only a limit was reported (the forecaster's own chance of this, stated with the estimate: 30%); at least 1.4-fold (0.15 log units) between middle value and limit.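

In this assay compound 3 gives > 50 mg/kg, which is a limit of the assay and not a number. Compound 2 also stands only at a limit, and no step can be read between compound 2 and compound 3. Still open, going by these compounds, is how far, if at all, replacing propanoyl with pyridin-3-yl on this nitrogen shifts the required dose.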